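Compound 3: from sulfonamide to pyrimidin-5-yl amine

This account rests on a few compounds, and the source may have more. Where it says the series, first, only, none or still open, it means among the compounds named here.

Compound 1 `C[C@@H](Cn1ccc(-c2ccc(C#N)c(Cl)c2)n1)NS(=O)(=O)c1cccnc1` in a functional assay on VCaP cells (Homo sapiens) for antiproliferative activity, read by CCK-8 assay, with a stated time of 6 days (a higher number here means a weaker inhibitor, a lower number a stronger inhibitor), gives 2450 nM
Compound 2 `C[C@@H](Cn1ccc(-c2ccc(C#N)c(Cl)c2)n1)NS(=O)(=O)c1cn(C)cn1` in this assay gives 13600 nM

Of the two measured compounds, compound 2 stands at the higher number, 13600 nM, and so at the weaker end of this small set. The next structure is compound 3 `C[C@@H](Cn1ccc(-c2ccc(C#N)c(Cl)c2)n1)Nc1cncnc1`, with pyrimidin-5-yl in place of (1-methyl-1H-imidazol-4-yl)sulfonyl on an amine nitrogen.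

Within the data shown here, only one measured step bears on this change, and it does so indirectly. That step, a 5.6-fold higher number from compound 1 to compound 2 (0.74 log units; beyond the scatter), is modest but beyond the scatter, and it swaps only the group on the sulfonyl sulfur. Among the measured compounds shown here, no measured compound lacks the sulfonyl, so the size of this change is poorly constrained. A modest step towards a lower number is expected, with compound 1 at 2450 nM as the only reference point on that side. The expected step is a 2.3-fold lower number from compound 2 to compound 3 (0.36 log units; beyond the scatter). For compound 3 the estimated value in this assay is 6000 nM, with an expected range of 1500 nM to 24000 nM.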

Compound 3, half-maximal inhibitory concentration: > 30000 nM
Compound 3: no number, only a limit; the forecaster's own chance of this, stated with the estimate: 10%; middle value at least 5.0-fold (0.69 log units) from the limit.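

In this assay compound 3 gives only a limit of the assay, not a number: the limit of > 30000 nM in this assay, at which 1 of the 3 values shown sits.

Taken as a lower bound, the change to pyrimidin-5-yl on the amine nitrogen gives an at least 2.2-fold higher number from compound 2 to compound 3 (0.34 log units; beyond the scatter), and the same comparison with the other sulfonamide gives an at least 12-fold higher number from compound 1 to compound 3 (1.08 log units; beyond the scatter). The earlier step varied only the ring on the sulfonyl sulfur, whereas these steps remove the sulfonyl and show that, among the three compounds here, only the two sulfonamides reach a number in this read-out, so the series does not tolerate this replacement on the amine nitrogen at the concentrations that the limit covers.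

The sulfonyl and the ring change together in both steps, so the compounds shown do not separate the loss of the sulfonyl from the change to pyrimidin-5-yl, a question that a pyridin-3-yl set directly on the amine nitrogen, or a carbonyl link carrying the same ring, would address. As far as these compounds go, how far compound 3 lies beyond its limit also stays open, and with it the true size of both steps.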